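Thiophen-2-yl to Furan-2-yl: From Compound 3 to Compound 4

The source may hold more compounds than are shown below. What is called first, only, known or untested is meant among the compounds shown, and "the series" means these compounds.

Compound 1 `Oc1ccc(-c2cc(-c3cccnc3)nc(-c3ccccc3Cl)c2)cc1` gives "not determined" (no result reported) in a functional assay on DU-145 cells (Homo sapiens) for cytotoxicity, read by CCK-8 assay and cell counting, with a stated time of 2 days (on this read-out lower numbers stand for stronger inhibition and higher numbers for weaker inhibition), so it has no reported result there. Compound 2 `Oc1cccc(-c2cc(-c3ccc(Cl)cc3)nc(-c3cccs3)c2)c1` gives 11600 nM in this assay, and compound 3 `Oc1cccc(-c2cc(-c3cccc(Cl)c3)nc(-c3cccs3)c2)c1` gives 2650 nM. Within the data shown here, the only measured one-place step, a 4.4-fold lower number from compound 2 to compound 3 (0.64 log units; beyond the scatter), moves the chlorine on one phenyl group. Compound 3 therefore stands at the lowest of the two numbers, with compound 2 the nearest. Compound 4 `Oc1cccc(-c2cc(-c3cccc(Cl)c3)nc(-c3ccco3)c2)c1` differs from compound 3 by furan-2-yl in place of thiophen-2-yl on an aromatic carbon. Among the measured compounds shown here, no measured step touches this five-membered ring, so the single measured step gives no direct guide, and the two groups differ only in their hetero atom. Compound 4 is therefore expected to sit close to compound 3, with a 1.1-fold higher number from compound 3 to compound 4 (0.05 log units; within the scatter) lying within the scatter. The estimate for compound 4 in this assay is 3000 nM, ranging from 1000 nM to 9000 nM.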

Compound 4, half-maximal inhibitory concentration: 2020 nM
The estimate for compound 4 lay 1.5-fold (0.17 log units) above the measured number; the range from low to high includes it.
By their numbers in this assay, from the lowest: compounds 4 and 3 (each within the scatter of the next); then compound 2.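

At this position, next to the ring nitrogen, furan-2-yl in place of thiophen-2-yl gives a 1.3-fold lower number from compound 3 to compound 4 (0.12 log units; within the scatter) in this assay. Among these compounds, exchanging the sulfur of the five-membered aromatic ring for oxygen therefore yields two compounds that cannot be told apart here, and this is the first measured step to touch that ring. Nothing shown explains this match. Going by these compounds, it remains open how this position responds to a group other than a five-membered aromatic ring, such as an amine or a longer alkyl chain. On these data alone, it also remains open whether furan-2-yl and thiophen-2-yl still match alongside the 4-chlorophenyl group of compound 2.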